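A Second Fluorine on the Triazole Aryl Group

The source may report more compounds than this note shows. Statements on the series, on what has been measured and on what is new or still open speak of the compounds shown alone.

Compound 1 `Cc1ccccc1-n1nncc1CN1C(=O)C2(C(C#N)=C(N)Oc3c2c2nc4ccccc4nc2c2ccccc32)c2ccccc21`, compound 2 `N#CC1=C(N)Oc2c(c3nc4ccccc4nc3c3ccccc23)C12C(=O)N(Cc1cnnn1-c1ccc(F)cc1)c1ccccc12` and compound 3 `N#CC1=C(N)Oc2c(N)cc3nc4ccccc4nc3c2C12C(=O)N(Cc1cnnn1-c1ccc(F)cc1)c1ccccc12` share one core and were all tested in a functional assay on HCT-116 cells (Homo sapiens) for antiproliferative activity, read by MTT assay, with a stated time of 48 h; on this read-out higher numbers stand for weaker inhibition and lower numbers for stronger inhibition. In this assay compound 1 returns only a limit of the assay, > 50000 nM. Compound 2 likewise returns only a limit, > 50000 nM. Compound 3 too gives only a limit, > 50000 nM. The step that the two limits leave unreadable from compound 1 to compound 2 is therefore not readable, since both of its ends are limits. Compound 3 thus stands at the limit of > 50000 nM in this assay, at which 3 of the 3 values shown sit, alongside every other value shown, and no number separates it from its neighbours.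

Compound 4 `N#CC1=C(N)Oc2c(N)cc3nc4ccccc4nc3c2C12C(=O)N(Cc1cnnn1-c1c(F)cccc1F)c1ccccc12` differs from compound 3 by 2,6-difluorophenyl in place of 4-fluorophenyl on an aromatic nitrogen. Within the data shown here, no measured step touches this change: the one step recorded concerns a different aryl group on the same aromatic nitrogen and is itself unreadable. Nothing in the data therefore predicts a move in this assay in either direction, and the expectation rests only on the fact that every measured neighbour sits at the limit.

Compound 4 is accordingly expected to stay at or near that limit, with an estimated value of 80000 nM in this assay, ranging from 30000 nM to 300000 nM. The step that the limit leaves unreadable from compound 3 to compound 4 is expected to amount to nothing beyond the scatter.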

Compound 4, half-maximal inhibitory concentration: > 50000 nM
Compound 4: a limit, no number; the forecaster's own chance of this, stated with the estimate: 80%; the middle value lies beyond the limit too.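

In this assay compound 4 returns only a limit of the assay, > 50000 nM. Compound 3 also sits at a limit, so the step between compound 3 and compound 4 cannot be read. The compounds shown give no number: the limit of > 50000 nM in this assay, at which 4 of the 4 values shown sit. They leave open whether the aryl group on the aromatic nitrogen changes the outcome in this assay at all.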